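From 2-acetoxyphenyl to 4-fluorophenyl at the measurement limit

This account rests on a few compounds, and the source may have more. Where it says the series, first, only, none or still open, it means among the compounds named here.

Values in an ADME assay on HEK-293T cells (Homo sapiens) for cytotoxicity, read by MTT assay, with a stated time of 3 days (a lower number here means that less compound is tolerated, a higher number that more compound is tolerated), each one a limit:
Compound 1 `CC(C)(C)N(Cc1ccc([N+](=O)[O-])cc1)C(=O)COC(=O)c1ccc([N+](=O)[O-])o1`: > 100000 nM
Compound 2 `CC(=O)Oc1ccccc1CN(C(=O)COC(=O)c1ccc([N+](=O)[O-])o1)C(C)(C)C`: > 100000 nM

Compound 2 gives only a limit, > 100000 nM, not a number. Compound 3 `CC(C)(C)N(Cc1ccc(F)cc1)C(=O)COC(=O)c1ccc([N+](=O)[O-])o1` carries 4-fluorophenyl in place of 2-acetoxyphenyl on a saturated chain carbon bound to an amide-type nitrogen. Within the data shown here, the only measured change at this place is a step that the two limits leave unreadable from compound 1 to compound 2. The evidence is the limit of > 100000 nM in this assay, at which 2 of the 2 values shown sit, so it offers no size to carry over, and no step beyond the scatter is expected in this assay. The expected step is a number no higher from compound 2 to compound 3 (the limit leaves the size open). Compound 3 is estimated at 100000 nM, within a range of 40000 nM to 200000 nM.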

Compound 3, half-maximal cytotoxic concentration: > 100000 nM
Compound 3: a limit, no number; the forecaster's own chance of this, stated with the estimate: 80%; the middle value sits exactly at the limit.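

No new step can be read among compound 1, compound 2 and compound 3 in this assay, since each result is a limit and not a number: the limit of > 100000 nM in this assay, at which 3 of the 3 values shown sit.

The compounds shown leave open at what concentration any of them harms the cells, and so whether exchanging these groups changes that concentration at all.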